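A few compounds are considered here, and "the series" means these few. Any claim that something is new, unique, unknown or untested is made for them only; others in the source may bear on it.

Working notes on the series in a functional assay on the whole organism with Rattus norvegicus as the target, at a dose of 40 mg/kg by the intraperitoneal route; on this read-out lower numbers stand for less inhibition and higher numbers for more inhibition at the one dose given (going by the name of the read-out). Compound 1 `Cc1nc2c(Oc3ccccc3)cccn2c1N` gives 34% in this assay, and compound 2 `Cc1nc2c(OCc3ccccc3)cccn2c1CN` gives 46%. Compound 2 holds the higher of the two numbers, with compound 1 beyond the scatter below it. Compound 3 `Cc1nc2c(OCc3ccccc3)cccn2c1NCc1ccccc1` is not yet measured; it differs from compound 2 by benzylamino in place of aminomethyl on an aromatic carbon. Going by the values given here, no measured pair shows the effect of this change, so the step of a number 1 percentage points lower from compound 2 to compound 3 (within the scatter) is expected to stay within the scatter rather than move in either direction. Compound 3 is therefore estimated at 45%, with a range from 20% to 70%.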

Compound 3, a percentage reported as inhibition, in the whole organism at one dose (the size of the read-out at that dose, not a potency): 48%
Estimate against measurement, compound 3: 3 percentage points below; the measured number falls inside the stated range.
By their numbers in this assay, from the lowest: compound 1; then compounds 2 and 3 (each within the scatter of the next).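

Benzylamino in place of aminomethyl on an aromatic carbon gives a number 2 percentage points higher from compound 2 to compound 3 (within the scatter) in this assay. This position of the five-membered aromatic ring therefore accepts a much larger group, bearing a six-membered aromatic ring of carbon only, with no step beyond the scatter at the one dose given. No available evidence bears on this result.

On these data alone, it remains open whether an amide or a carboxylic acid at this position would keep the read-out in the same band. The same holds for a longer chain between the amine nitrogen and the ring.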